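Replacing the amino group of compound 2

A few compounds are considered here, and "the series" means these few. Any claim that something is new, unique, unknown or untested is made for them only; others in the source may bear on it.

Measured in a functional assay on HT-29 cells (Homo sapiens) for cytotoxicity, read by MTT assay, with a stated time of 6 days; on this read-out lower numbers stand for an effect already at smaller amounts and higher numbers for an effect only at larger amounts of compound:
Compound 1 `O=c1cc(-c2ccc([N+](=O)[O-])cc2)oc2cc(O)ccc12`: 6.95 ug/mL
Compound 2 `Nc1ccc(-c2cc(=O)c3ccc(O)cc3o2)cc1`: 4.71 ug/mL
Compound 3 `COc1cc(-c2cc(=O)c3ccc(OC(C)=O)cc3o2)cc(OC)c1O`: > 25 ug/mL (a limit, not a number)

Only compound 1 and compound 2 have actual numbers, and these two lie within the scatter of each other. Compound 3 gives only a limit, (the limit of > 25 ug/mL in this assay, at which 1 of the 3 values shown sits).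

Compound 4 `CC(C)(C)[Si](C)(C)Oc1ccc(-c2cc(=O)c3ccc(O)cc3o2)cc1` keeps the core of compound 2 and changes one group: a group of 8 heavy atoms (6 carbon, 1 oxygen, 1 silicon; no ring) in place of one nitrogen atom, on an aromatic carbon. The new group sits on an aromatic carbon, para to a large group.

Among the compounds with values here, one measured step bears on this change: a 1.5-fold lower number from compound 1 to compound 2 (0.17 log units; within the scatter). It also swaps one group on an aromatic carbon, but the group entering compound 4 is of a very different kind, so this step is only a weak guide. A modest move towards a higher number in this assay is expected, with wide uncertainty: a 2.1-fold higher number from compound 2 to compound 4 (0.33 log units; beyond the scatter). For compound 4 the estimated value is 10 ug/mL, with an expected range from 3 ug/mL to 30 ug/mL.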

Compound 4, concentration for half-maximal effect: 3.61 ug/mL
Compound 4: the middle estimate sits 2.8-fold (0.44 log units) above what was measured; the range from low to high includes it.
By their numbers in this assay, from the lowest: compounds 4, 2 and 1 (each within the scatter of the next). At a limit, above all of these: compound 3.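

Until now this position had only been probed with amino and nitro; compound 4 carries a silicon-containing group of 8 heavy atoms on the same aromatic carbon, para to a large group, and it has 0 hydrogen-bond donors where amino has 1. In this assay that much larger swap still gives a 1.3-fold lower number from compound 2 to compound 4 (0.12 log units; within the scatter), and against the nitro group it gives a 1.9-fold lower number from compound 1 to compound 4 (0.28 log units; within the scatter), so all three groups fit on this carbon with no difference that can be told from the scatter. Nothing measured here gives a reason for this.

As far as these compounds go, whether a free hydroxyl, a carboxylic acid or a longer alkyl chain on this carbon would also stay within the scatter remains open. So does whether any group here can move the number at all.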